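This account rests on a few compounds, and the source may have more. Where it says the series, first, only, none or still open, it means among the compounds named here.

Working notes on the series. In a functional assay on ACHN cells (Homo sapiens) for cytotoxicity, read by sulforhodamine B assay, tested at 10 uM (on this read-out higher numbers stand for more inhibition at the one concentration tested (going by the name of the read-out) and lower numbers for less inhibition), compound 1 `CC(=O)OC[C@H]1O[C@@H](n2cc(-c3cn(Cc4ccc(C(C)C)cc4)nn3)c(=O)[nH]c2=O)C[C@@H]1OC(C)=O` gives 92.2% and compound 3 `CC(C)(C)c1ccc(-c2cc(-c3cn([C@H]4C[C@H](O)[C@@H](CO)O4)c(=O)[nH]c3=O)on2)cc1` gives 94.2%. Compound 2 `CC(=O)OC[C@H]1O[C@@H](n2cc(-c3cc(-c4ccc(C(C)(C)C)cc4)no3)c(=O)[nH]c2=O)C[C@@H]1OC(C)=O` stands lowest of the three measured numbers in this assay, with 74.7%; its nearest neighbour is compound 1, higher by an amount beyond the scatter, and compound 3 lies further still, also beyond the scatter.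

Compound 4 `CC(=O)OC[C@H]1O[C@@H](n2cc(-c3cc(-c4ccc(C(C)C)cc4)no3)c(=O)[nH]c2=O)C[C@@H]1OC(C)=O` has not been measured. It differs from compound 2 in one place: hydrogen in place of methyl on a saturated chain carbon bound to an aromatic carbon and two saturated chain carbons. Going by the values given here, no pair of measured compounds isolates this change, so its size cannot be read from the numbers in hand; tert-butyl to isopropyl, with all else held, is a small change on the saturated chain carbon bound to an aromatic carbon and two saturated chain carbons. The expectation in this assay is therefore a step from compound 2 to compound 4 of a number 3.3 percentage points higher from compound 2 to compound 4 (within the scatter), not beyond the scatter, in either direction. Compound 4 is estimated at 78%, with a range from 62% to 92%.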

Compound 4, a percentage reported as inhibition, at one concentration (the size of the read-out at that concentration, not a potency): 90.1%
For compound 4 the middle estimate is 12.1 percentage points below the measured one; the measured number falls inside the stated range.
By their numbers in this assay, from the lowest: compound 2; then compounds 4, 1 and 3 (each within the scatter of the next).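

In this assay the change from tert-butyl to isopropyl reads as a number 15.4 percentage points higher from compound 2 to compound 4 (beyond the scatter) and so shows that removing one methyl at this position, on the saturated chain carbon bound to an aromatic carbon and two saturated chain carbons, moves the read-out by more than the scatter. Going by these compounds alone, no earlier pair differed in one place, so this is the first single change whose size can be read, though it rests on one pair and one background. Nothing measured here bears on why the read-out moves with this change.

On these data alone, whether the same step holds on the core of compound 3 remains open. Also open, as far as these compounds go, is how the read-out responds at this position to an ethyl group, a cyclopropyl group or an amine.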